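The compounds below may be only part of what the source reports. "The series", "measured", "known", "first", "only" and "open" are said of these compounds alone.

Measured so far in a functional assay on K562 cells (Homo sapiens) for antiproliferative activity, read by MTT assay, with a stated time of 48 h; on this read-out higher numbers stand for weaker inhibition and lower numbers for stronger inhibition:
compound 1, `Cc1nc2ccccc2nc1Oc1ccc(C(=O)N[C@@H](CC(C)C)C(=O)O)cc1`, gives 19500 nM;
compound 2, `CC[C@@H](C)[C@H](NC(=O)c1ccc(Oc2nc3ccccc3nc2C)cc1)C(=O)O`, gives 30500 nM;
compound 3, `CC[C@@H](C)[C@H](NC(=O)c1ccc(Oc2nc3ccccc3nc2NC(C)(C)C)cc1)C(=O)O`, gives 18300 nM.

Compound 4, `CC(C)C[C@H](NC(=O)c1ccc(Oc2nc3ccccc3nc2NC(C)(C)C)cc1)C(=O)O`, awaits measurement in this assay. It differs from compound 3 by isobutyl in place of sec-butyl on a saturated chain carbon bound to an amide-type nitrogen and a carbonyl carbon. The same change has been made once before, from compound 2 to compound 1, where it read isobutyl in place of sec-butyl on a saturated chain carbon bound to an amide-type nitrogen and a carbonyl carbon and produced a 1.6-fold lower number from compound 2 to compound 1 (0.19 log units; within the scatter). The place of the change is described in the same words for both pairs, so it is the same change, but the cores differ: compound 3 carries (tert-butyl)amino in place of methyl on an aromatic carbon, a difference that gave a 1.7-fold lower number from compound 2 to compound 3 (0.22 log units; within the scatter). Because the earlier instance gave a 1.6-fold lower number from compound 2 to compound 1 (0.19 log units; within the scatter), compound 4 is expected to show a 1.5-fold lower number from compound 3 to compound 4 (0.18 log units; within the scatter) in this assay. Compound 4 is therefore estimated at 12000 nM, with a likely range from 5000 nM to 30000 nM.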

Compound 4, half-maximal inhibitory concentration: 42300 nM
Compound 4: the middle estimate sits 3.5-fold (0.55 log units) below what was measured; the whole stated range lies below it.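

In this assay, isobutyl in place of sec-butyl gives a 2.3-fold higher number from compound 3 to compound 4 (0.36 log units; beyond the scatter), so the change does not read the same on the core of compound 3 as on the core of compound 2: the same change on two cores in this assay, a 1.6-fold lower number (0.19 log units; within the scatter) from compound 2 to compound 1 and a 2.3-fold higher number (0.36 log units; beyond the scatter) from compound 3 to compound 4, 3.6-fold (0.56 log units) apart, beyond the scatter of two such steps
Seen from the other side, (tert-butyl)amino in place of methyl on an aromatic carbon gives a 2.2-fold higher number from compound 1 to compound 4 (0.34 log units; beyond the scatter), and this step also differs from its earlier counterpart: the same change on two cores in this assay, a 1.7-fold lower number (0.22 log units; within the scatter) from compound 2 to compound 3 and a 2.2-fold higher number (0.34 log units; beyond the scatter) from compound 1 to compound 4, 3.6-fold (0.56 log units) apart, beyond the scatter of two such steps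
The four compounds show that neither change carried over unaltered between these two backgrounds, but they do not show why, nor how either change would behave on any further core.

As far as these compounds go, it remains open whether the same reversal would appear with a cyclohexylamine or a morpholine in place of (tert-butyl)amino. Also open, from the compounds shown here alone, is whether it would persist with a methyl ester or a primary amide in place of the carboxylic acid.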